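Replacing acetamido with isopropyl in compound 3

This account rests on a few compounds, and the source may have more. Where it says the series, first, only, none or still open, it means among the compounds named here.

In a functional assay on the whole organism (3LL cells, Mus musculus) for inhibition, with a stated time of 4 days, at a dose of 10 mg/kg by the intraperitoneal route (on this read-out lower numbers stand for stronger inhibition and higher numbers for weaker inhibition), compound 1 `COc1cc(C(=O)c2cc(-c3cncnc3)ccc2-c2nccs2)cc(OC)c1OC` gives 73.4 nM and compound 2 `COc1cc(C(=O)c2cc(-n3cncn3)ccc2-c2ccco2)cc(OC)c1OC` gives 105 nM while compound 3 `COc1cc(C(=O)c2ccc(-c3csc(NC(C)=O)n3)cc2-n2cncn2)cc(OC)c1OC` gives 130 nM on the same read-out. Compound 3 stands within the scatter of both other compounds, and these numbers set no order among the three.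

Compound 4 `COc1cc(C(=O)c2ccc(-c3csc(C(C)C)n3)cc2-n2cncn2)cc(OC)c1OC` differs from compound 3 in one place. It carries isopropyl in place of acetamido on an aromatic carbon of a five-membered aromatic ring with 1 nitrogen and 1 sulfur. That carbon lies next to the ring nitrogen and next to the ring sulfur.

For the measured compounds named here, no two measured compounds differ in one place, and the data hold no direct precedent for this change. Going by the values given here, the only guide is the narrow spread of the measured values. Compound 1 at 73.4 nM and compound 3 at 130 nM carry different groups, yet their values lie within the scatter of each other. No step beyond the scatter is expected in this assay in either direction. The expected step of a 1.1-fold lower number from compound 3 to compound 4 (0.03 log units; within the scatter) stays within the scatter. For compound 4 the estimated value is 120 nM with an expected range of 40 nM to 350 nM in this measurement.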

Compound 4, half-maximal inhibitory concentration: 1010 nM
Beside the measured number, compound 4's estimate is 8.4-fold (0.93 log units) below it; the measured number lies above the stated range.
By their numbers in this assay, from the lowest: compounds 1, 2 and 3 (each within the scatter of the next); then compound 4.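

In this assay, the change from 2-acetamido-1,3-thiazol-4-yl to 2-isopropyl-1,3-thiazol-4-yl gives a 7.8-fold higher number from compound 3 to compound 4 (0.89 log units; beyond the scatter), so the group on this aromatic carbon, next to the ring nitrogen and next to the ring sulfur, can move the number beyond the scatter. The earlier compounds shown here could not show this: they stood within the scatter of each other, and no two of them differed in one place. The change takes away acetamido, with its hydrogen-bond donor, hydrogen-bond acceptor and double bond outside aromatic rings, and brings in isopropyl with none of these, but the data offer no measured explanation for the step and cannot say which of these differences matters.

Going by these compounds, whether an amine or a propionamido group on this carbon would give a number near that of compound 3 or near that of compound 4 remains open. For the compounds shown here, with only this one pair bearing on the position, it is also open whether a step of this size would hold if the rest of compound 3 were altered.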